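Furoxan-linked series: alanine for glycine linker variant

The compounds below may be only part of what the source reports. "The series", "measured", "known", "first", "only" and "open" are said of these compounds alone.

Measured so far:
compound 1 `CC1(C)CCC(C)(C)c2cc(NC(=O)c3ccc(C(=O)OCCOC(=O)c4ccc(OCc5c(-c6ccccc6)no[n+]5[O-])cc4)cc3)ccc21`: 119000 nM
compound 2 `CC1(C)CCC(C)(C)c2cc(NC(=O)c3ccc(C(=O)NCC(=O)OCc4c(-c5ccccc5)no[n+]4[O-])cc3)ccc21`: 190 nM
compound 3 `CC1(C)CCC(C)(C)c2cc(NC(=O)c3ccc(C(=O)OCCCCCOC(=O)c4ccc(OCc5c(-c6ccccc6)no[n+]5[O-])cc4)cc3)ccc21`: 240000 nM

In a functional assay on NB-4 cells (Homo sapiens) for antiproliferative activity, read by MTT assay, with a stated time of 48 h (a lower number here means a stronger inhibitor, a higher number a weaker inhibitor), compound 2 gives the lowest number of the three and is the strongest inhibitor here; compound 1 and compound 3, which carry ester-linked chains of different length, both sit far beyond the scatter above it.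

Compound 4 `C[C@H](NC(=O)c1ccc(C(=O)Nc2ccc3c(c2)C(C)(C)CCC3(C)C)cc1)C(=O)OCc1c(-c2ccccc2)no[n+]1[O-]` is not yet measured. It differs from compound 2 by methyl in place of hydrogen on a saturated chain carbon bound to an amide-type nitrogen and a carbonyl carbon. Within the data shown here, no step between measured compounds resembles this change, so the expectation rests on compound 2 alone.

Compound 4 is expected to stay close to compound 2, with a step of a 1.2-fold higher number from compound 2 to compound 4 (0.06 log units; within the scatter) in this assay that lies within the scatter, in no clear direction. The estimated value for compound 4 is 220 nM, with a range from 80 nM to 600 nM.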

Compound 4, half-maximal inhibitory concentration: 5100 nM
The estimate for compound 4 lay 23-fold (1.37 log units) below the measured number; the whole stated range lies below it.
By their numbers in this assay, from the lowest: compound 2; then compound 4; then compounds 1 and 3 (each within the scatter of the next).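

In this assay, methyl in place of hydrogen on the saturated chain carbon bound to an amide-type nitrogen and a carbonyl carbon gives a 27-fold higher number from compound 2 to compound 4 (1.43 log units; beyond the scatter), a large loss from a single added carbon. The earlier compounds shown here held no change at this carbon, and this step marks it as a sensitive point in the linker of compound 2. No measurement at hand explains the size of this step. Open, from the compounds shown here alone, is whether an ethyl or hydroxymethyl group on this carbon would fall in line with methyl, and whether the mirror-image form of compound 4 would give a similar number.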